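The compounds below may be only part of what the source reports. "The series", "measured", "known", "first", "only" and "open" are said of these compounds alone.

The study gathers three measured compounds and one that still awaits measurement in a functional assay on HT-29 cells (Homo sapiens) for antiproliferative activity, read by MTT assay, with a stated time of 72 h; on this read-out lower numbers stand for stronger inhibition of growth and higher numbers for weaker inhibition of growth. Compound 1 `COc1cc(OC)n2cc(-c3ccc(NCc4ccccc4)cc3)nc2n1` rests on a core of its own, and in this assay compound 1 gives only a limit of the assay, > 100000 nM. Compound 2 `COc1cc(OC)n2cc(-c3ccc(N(Cc4ccccc4)Cc4ccccc4)cc3)nc2n1` differs from compound 1 by benzyl in place of hydrogen on a nitrogen on an aromatic ring, and in this assay compound 2 likewise gives only a limit, > 100000 nM. The step that the two limits leave unreadable from compound 1 to compound 2 therefore cannot be read, because both values sit at the limit of > 100000 nM in this assay, at which 2 of the 3 values shown sit.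

Compound 3 `Cc1ccc2nc(-c3ccc(NCc4ccccc4)cc3)cn2c1` stands on a different core; the difference between the two cores is not broken down here. In this assay, going by the values given here, compound 3 gives 8800 nM, the only number among the three values shown.

Compound 4 `Cc1ccc2nc(-c3ccc(N(Cc4ccccc4)Cc4ccccc4)cc3)cn2c1` is not yet measured. It differs from compound 3 by benzyl in place of hydrogen on a nitrogen on an aromatic ring, the same change as that made from compound 1 to compound 2, so this change occurs twice in all among the compounds here; the earlier instance gave no readable size. What is expected for compound 4 rests on compound 3 with its 8800 nM and on the earlier pair offering no size to read. The step is expected to be about a 1.4-fold higher number from compound 3 to compound 4 (0.13 log units; within the scatter). Compound 4 is thus estimated at 12000 nM, with a likely range from 3000 nM to 60000 nM.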

Compound 4, concentration for 50% growth inhibition: 37600 nM
Compound 4: middle estimate off by 3.1-fold (0.50 log units), on the low side; the measured number falls inside the stated range.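

On the core of compound 3, benzyl in place of hydrogen on the nitrogen gives a 4.3-fold higher number from compound 3 to compound 4 (0.63 log units; beyond the scatter) in this assay, so on this core the second benzyl goes with weaker inhibition of growth, by a modest step that stands clear of the usual scatter. The same change on the core of compound 1 cannot be read and offers no size to set beside that step, because both values there are limits and not numbers: the limit of > 100000 nM in this assay, at which 2 of the 4 values shown sit. The series therefore gives the size of this change on one core only; it shows neither that the step carries from one core to the other nor that it fails to, and a single readable pair supports no rule for the change.

The compounds shown leave open how a methyl group, an acetyl group or a longer chain such as phenethyl on that same nitrogen would read on the core of compound 3, and so whether the step belongs to benzyl in particular. They also leave open whether an added amine or carboxylic acid on the core of compound 1 would bring its values off the limit and make the change readable there.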